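The compounds below may be only part of what the source reports. "The series", "measured", "known", "first", "only" and "open" are said of these compounds alone.

Compound 3 `CC(=O)NCCCCCCCCCCCCCCC/C=C1\CC(CO)(COC(=O)C(C)(C)C)OC1=O` gives the highest number of the three in a functional assay on MOLT-4F cells (Homo sapiens) for antiproliferative activity (a higher number here means a weaker inhibitor of growth, a lower number a stronger inhibitor of growth), at 6.35 ug/mL; compound 2 `CC(=O)OCCCCCCCCCCCCCCC/C=C1\CC(CO)(COC(=O)C(C)(C)C)OC1=O` gives 1.55 ug/mL, and compound 1 `CC(C)(C)C(=O)OCC1(CO)C/C(=C\CCCCCCCCCCCO)C(=O)O1` gives 1.34 ug/mL. Compound 4 `CC(C)(C)C(=O)OCCCCCCCCCCCCCCC/C=C1\CC(CO)(COC(=O)C(C)(C)C)OC1=O` differs from compound 3 in one place: ((tert-butyl)carbonyl)oxy in place of acetamido on a saturated chain carbon, ten or more bonds along the chain from a double-bonded chain carbon. Going by the values given here, two measured steps bear on this. The step of a 4.1-fold higher number from compound 2 to compound 3 (0.61 log units; beyond the scatter) runs the opposite way, acetoxy giving way to acetamido, and a 1.2-fold higher number from compound 1 to compound 2 (0.06 log units; within the scatter) shows that acetoxy and hydroxy on that saturated chain carbon sit within the scatter of each other. Replacing the amide with an ester is therefore expected to bring the number back down by roughly the size of the earlier amide step, so a 4.0-fold lower number from compound 3 to compound 4 (0.60 log units; beyond the scatter) is the expected step. Compound 4 is estimated at 1.6 ug/mL in this assay, with a range of 0.8 ug/mL to 3.5 ug/mL.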

Compound 4, concentration for 50% growth inhibition: 0.605 ug/mL
Compound 4: middle estimate off by 2.6-fold (0.42 log units), on the high side; the whole stated range lies above it.
By their numbers in this assay, from the lowest: compound 4; then compounds 1 and 2 (each within the scatter of the next); then compound 3.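

In this assay, swapping the amide end group for the tert-butyl ester on this saturated chain carbon does more than recover the acetate level (a 10-fold lower number from compound 3 to compound 4 (1.02 log units; beyond the scatter)). The acyl part of the ester also matters here, as the tert-butyl ester separates from the acetate (a 2.6-fold lower number from compound 2 to compound 4 (0.41 log units; beyond the scatter)) and from the hydroxy-ended compound (a 2.2-fold lower number from compound 1 to compound 4 (0.35 log units; beyond the scatter)), making compound 4 the lowest of the four. No measurement shown accounts for these differences.

Still open, as far as these compounds go, is whether a benzoate ester or a bulkier acyl group would lower the number further. From the compounds shown here alone, a primary amine or a carboxylic acid at this chain end also remains untested in these data.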